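Oxiran-2-yl in Place of Pentyl in a Leukotriene Series

The compounds below may be only part of what the source reports. "The series", "measured", "known", "first", "only" and "open" are said of these compounds alone.

Measured in an assay on isolated protein for inhibition of leukotriene B4 receptor 1 (Homo sapiens), tested at 10 uM; on this read-out lower numbers stand for less inhibition and higher numbers for more inhibition at the one concentration tested (going by the name of the read-out):
- compound 1, `CC(=O)c1cc(C)c(OCCCCC#N)cc1O`: 79%
- compound 2, `CCCCCc1cc(C(C)=O)c(O)cc1OCCCCC#N`: 31%
- compound 3, `CCCCCCc1cc(C(C)=O)c(O)cc1OCCCCC#N`: 51%

Compound 3 stands second highest of the three: a number 28 percentage points lower from compound 1 to compound 3 (beyond the scatter), while a number 20 percentage points higher from compound 2 to compound 3 (beyond the scatter); the largest gap is a number 48 percentage points lower from compound 1 to compound 2 (beyond the scatter). Compound 4, `CC(=O)c1cc(CC2CO2)c(OCCCCC#N)cc1O`, differs from compound 3 in one place: oxiran-2-yl in place of pentyl on a saturated chain carbon bound to an aromatic carbon. Among the compounds with values here, the steps that bear on this change are those at the same saturated chain carbon, where a number 28 percentage points lower from compound 1 to compound 3 (beyond the scatter) and a number 48 percentage points lower from compound 1 to compound 2 (beyond the scatter), both lowering inhibition when a chain replaces hydrogen. With a smaller group now entering, a modest step is expected, with direction uncertain; compound 4 is estimated at 55%, between 30% and 80%, which means an expected a number 4 percentage points higher from compound 3 to compound 4 (within the scatter).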

Compound 4, a percentage reported as inhibition, at one concentration (the size of the read-out at that concentration, not a potency): 62%
Compound 4: the middle estimate sits 7 percentage points below what was measured; the range from low to high includes it.
By their numbers in this assay, from the lowest: compound 2; then compound 3; then compound 4; then compound 1.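

In this assay, oxiran-2-yl in place of pentyl gives a number 11 percentage points higher from compound 3 to compound 4 (beyond the scatter) and in place of butyl gives a number 31 percentage points higher from compound 2 to compound 4 (beyond the scatter), so at this saturated chain carbon the three-membered ring keeps more inhibition than either chain. Hydrogen still stands apart, with a number 17 percentage points lower from compound 1 to compound 4 (beyond the scatter) for oxiran-2-yl in its place, so all three groups shown lower the number relative to hydrogen. No measurement at hand accounts for these steps. As far as these compounds go, whether the ring or its oxygen carries the gain stays open, as cyclopropyl would show, and so does how an amine would fare at this carbon.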